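Chloro to trifluoromethyl, carried onto a second core

A few compounds are considered here, and "the series" means these few. Any claim that something is new, unique, unknown or untested is made for them only; others in the source may bear on it.

Compound 1 `Cc1ccc(-c2ncccn2)c(C(=O)N2CC3(CC3)C[C@H]2CNc2ccc(Cl)cn2)c1` and compound 2 `Cc1ccc(-c2ncccn2)c(C(=O)N2CC3(CC3)C[C@H]2CNc2ccc(C(F)(F)F)cn2)c1` share one core and differ in a single group: trifluoromethyl in place of chloro on an aromatic carbon. In a functional assay on CHO cells for antagonist activity at Orexin/Hypocretin receptor type 1 (Homo sapiens), read by FLIPR and calcium flux (on this read-out lower numbers stand for lower potency and higher numbers for higher potency (the scale is a negative logarithm)), compound 1 gives 8.2, and compound 2 gives 8.7. That single exchange made a number 0.50 log units higher from compound 1 to compound 2 (beyond the scatter).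

Compound 3 `Cc1nc(C(=O)N2CC3(CC3)C[C@H]2CNc2ccc(Cl)cn2)c(-c2ccccc2)s1` is built on a different core; how the two cores differ is not broken down here. In this assay compound 3 gives 8.3. Compared with compound 1 this lies within the usual scatter, so nothing separates the two, whereas the gap to compound 2 is larger than the scatter.

Compound 4 `Cc1nc(C(=O)N2CC3(CC3)C[C@H]2CNc2ccc(C(F)(F)F)cn2)c(-c2ccccc2)s1` has not yet been measured. It is compound 3 with the same exchange applied: trifluoromethyl in place of chloro on an aromatic carbon. The group that leaves, the group that enters and the place on the ring read the same as in the first pair, so this is the same change, now on the core of compound 3.

The expectation for compound 4 rests on compound 1 and compound 2, where this change gave a number 0.50 log units higher from compound 1 to compound 2 (beyond the scatter). Compound 4 is therefore expected to reach about 8.7 in this assay. The estimate for compound 4 spans from 8.3 to 9.1. The step this estimate implies is a number 0.40 log units higher from compound 3 to compound 4 (beyond the scatter), expected to be close to the earlier one.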

Compound 4, negative logarithm of the antagonist equilibrium constant: 8.4
Beside the measured number, compound 4's estimate is 0.30 log units above it, within the range that was stated.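

On the core of compound 3, the exchange of chloro for trifluoromethyl gave a number 0.10 log units higher from compound 3 to compound 4 (within the scatter), so in this assay the two compounds cannot be told apart by this step alone. Taken by itself, that might suggest the change does something on the first core and nothing on the second, but the two steps do not differ by more than measurements of this kind allow: the same change on two cores in this assay, a number 0.50 log units higher (beyond the scatter) from compound 1 to compound 2 and a number 0.10 log units higher (within the scatter) from compound 3 to compound 4, 0.40 log units apart, within the scatter of two such steps. Within the data shown here, this shows no measurable difference between the cores in how they respond to the change, yet it does not show that the step carries over at the same size, since one step lies beyond the scatter, the other lies within it, and only two pairs are available.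

The compounds shown leave open how the change would behave on any third core, where a further pair could help settle whether the step has one typical size in this series. They also leave open what other groups would do at the same place on the ring, such as a nitrile, a methoxy group or a bromo group in place of chloro, on either core.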